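Aryl replacement on the ring amine, compound 2 to compound 3

This account rests on a few compounds, and the source may have more. Where it says the series, first, only, none or still open, it means among the compounds named here.

Measured compounds:
compound 1, `Nc1scc(CN2CCN(c3ccc(Cl)cc3Cl)CC2)c1C(=O)c1ccc(Cl)cc1`: -11%
compound 2, `Nc1scc(CN2CCN(c3ccncc3)CC2)c1C(=O)c1ccc(Cl)cc1`: 1.4%

In a functional assay on CHO cells with adenosine receptor A1 (Homo sapiens) as the target, read by cAMP accumulation and immunoassay, with a stated time of 6 min, tested at 0.1 uM (a lower number here means a stronger effect, a higher number a weaker effect of the compound at the concentration tested), compound 1 gives -11% and compound 2 gives 1.4%. Among the measured compounds shown here, compound 2 stands highest of the two numbers; its only neighbour is compound 1, and the single measured step, a number 12.4 percentage points higher from compound 1 to compound 2 (beyond the scatter), lies beyond the scatter and is modest.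

Compound 3, `Nc1scc(CN2CCN(c3ccccc3F)CC2)c1C(=O)c1ccc(Cl)cc1`, is not yet measured. It differs from compound 2 by 2-fluorophenyl in place of pyridin-4-yl on an amine nitrogen in a ring. For the measured compounds named here, the one step that bears on it is the step from compound 1 to compound 2, in which a carbon-only aromatic ring on the ring amine was exchanged for pyridin-4-yl and the number rose modestly. Compound 3 places a carbon-only aromatic ring, 2-fluorophenyl, back on that nitrogen, so a move back toward the value of compound 1 is expected, though the two carbon-only rings are not the same and the step may be smaller. The expected step is a number 7.4 percentage points lower from compound 2 to compound 3 (within the scatter). Compound 3 is estimated at -6%, with a range from -20% to 8%.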

Compound 3, a percentage reported as activity, at one concentration (the size of the read-out at that concentration, not a potency): -1%
Compound 3: the middle estimate sits 5 percentage points below what was measured, within the range that was stated.
By their numbers in this assay, from the lowest: compounds 1, 3 and 2 (each within the scatter of the next, the first and the last beyond it).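

In this assay, 2-fluorophenyl in place of pyridin-4-yl on the amine nitrogen in the ring gives a number 2.4 percentage points lower from compound 2 to compound 3 (within the scatter), and 2-fluorophenyl in place of 2,4-dichlorophenyl gives a number 10 percentage points higher from compound 1 to compound 3 (within the scatter). A carbon-only aromatic ring at this position therefore does not separate from pyridin-4-yl, and the gap between compound 1 and compound 2 cannot be tied to the ring nitrogen of pyridin-4-yl alone. No measurement at hand accounts for these numbers.

From the compounds shown here alone, it remains open whether the gap between compound 1 and compound 2 follows the two chlorine atoms, and an unsubstituted phenyl or a 4-chlorophenyl on this nitrogen would bear on that. Going by these compounds, how a non-aromatic group there, such as a short alkyl chain or a carboxylic acid-bearing chain, would read is also open.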